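This account rests on a few compounds, and the source may have more. Where it says the series, first, only, none or still open, it means among the compounds named here.

Measured so far in an ADME assay on MT2 cells (Homo sapiens) for cytotoxicity, read by MTT assay; on this read-out higher numbers stand for lower toxicity in this test and lower numbers for higher toxicity in this test:
- compound 1 `N#Cc1ccc2c(Oc3ccc(F)cc3OCCn3ccc(=O)[nH]c3=O)cc(Cl)cc2c1` gives 16000 nM.
- compound 2 `O=c1ccn(CCOc2ccccc2Oc2cccc3ccccc23)c(=O)[nH]1` gives 80000 nM.
- compound 3 `O=c1ccn(CCOc2ccccc2Oc2cccc3cc(Cl)ccc23)c(=O)[nH]1` reaches only the limit > 100000 nM, not a number.

Compound 1 stands at the lowest of the two numbers, with compound 2 the nearest, at a higher number that lies beyond the scatter. For the measured compounds named here, the one step measured, an at least 1.2-fold higher number from compound 2 to compound 3 (0.09 log units; that floor lies within the scatter), sits at the floor of the scatter and is bounded by the limit of > 100000 nM in this assay, at which 1 of the 3 values shown sits.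

Compound 4 `N#Cc1ccc2c(Oc3ccc(F)cc3OCCn3ccc(=O)[nH]c3=O)cc(F)cc2c1` differs from compound 1 by fluoro in place of chloro on an aromatic carbon. Going by the values given here, no measured step exchanges one halogen for another; the closest, from compound 2 to compound 3, was too small to read. For compound 4 a step within the scatter is therefore expected, no change at the digits printed from compound 1 to compound 4 (within the scatter), giving an estimate of 16000 nM in this assay, with a range from 6000 nM to 45000 nM.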

Compound 4, half-maximal cytotoxic concentration: > 100000 nM
Compound 4: only a limit was reported; the forecaster's own chance of this, stated with the estimate: 5%; middle value at least 6.2-fold (0.79 log units) from the limit.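

At this position of the core of compound 1, para to a fused ring, the halogen alone separates the two compounds in this assay: fluoro in place of chloro gives an at least 6.2-fold higher number from compound 1 to compound 4 (0.79 log units; beyond the scatter). Compound 4 gives > 100000 nM, which is a limit and not a number. The step is thus only a floor, and its full size cannot be read: the limit of > 100000 nM in this assay, at which 2 of the 4 values shown sit.

Still open, going by these compounds, is how an amine or a methoxy group at this position would read on the same core. Also open, on these data alone, is whether the exchange of chloro for fluoro reads the same on a core without the nitrile.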